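Trifluoromethyl in Place of a Methylpyrazole: an Expected Loss

The source may report more compounds than this note shows. Statements on the series, on what has been measured and on what is new or still open speak of the compounds shown alone.

Compound 1, `Cc1ccc(-c2cc3nccc(-c4ccc(F)cc4)n3n2)cc1`: > 10000 nM
Compound 2, `COc1cc(-c2ccnc3cc(-c4ccc(-c5cnn(C)c5)cc4)nn23)cc(OC)c1OC`: 1240 nM

In a functional assay on B16-F0 cells (Mus musculus) for inhibition, read by CCK-8 assay, with a stated time of 48 h (on this read-out lower numbers stand for stronger inhibition and higher numbers for weaker inhibition), compound 1 gives > 10000 nM, which is a limit of the assay and not a number. Compound 1 therefore sits at the limit of > 10000 nM in this assay, at which 1 of the 2 values shown sits. For the measured compounds named here, compound 2 gives 1240 nM in this assay, the only number among the values shown. Compound 3, `COc1cc(-c2ccnc3cc(-c4ccc(C(F)(F)F)cc4)nn23)cc(OC)c1OC`, has not been measured; it differs from compound 2 by trifluoromethyl in place of 1-methyl-1H-pyrazol-4-yl on an aromatic carbon. Going by the values given here, no step between measured compounds is available, so there is nothing to carry over directly. In this assay the step from compound 2 to compound 3 is expected to be a modest loss, of size a 2.4-fold higher number from compound 2 to compound 3 (0.38 log units; beyond the scatter), somewhat beyond the usual scatter. Compound 3 is accordingly expected to give about 3000 nM, with a likely range from 800 nM to 12000 nM, and a fair chance that only a limit is reported.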

Compound 3, half-maximal inhibitory concentration: 1770 nM
Beside the measured number, compound 3's estimate is 1.7-fold (0.23 log units) above it, within the range that was stated.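

In this assay, this place on the six-membered aromatic ring of carbon only, para to a large group, now has its first readable step: a 1.4-fold higher number from compound 2 to compound 3 (0.15 log units; within the scatter). The 1-methyl-1H-pyrazol-4-yl, with its five-membered aromatic ring and hydrogen-bond acceptors, can therefore give way to trifluoromethyl, which has no ring and no acceptors, and the two values stay within the scatter of each other. Compound 1 differs from the other two in more than one place and still stands as a limit of the assay, not a number: the limit of > 10000 nM in this assay, at which 1 of the 3 values shown sits.

The compounds shown leave open whether a morpholine, a carboxylic acid or a plain hydrogen at this place would read the same in this assay. They also leave open whether this exchange would read the same on a different core.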